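This account rests on a few compounds, and the source may have more. Where it says the series, first, only, none or still open, it means among the compounds named here.

Of the compounds shown here, three sharing one core have been measured in a functional assay on IMR-32 cells (Homo sapiens) for cytotoxicity, read by sulforhodamine B assay, with a stated time of 48 h; a lower number here means a stronger inhibitor, a higher number a weaker inhibitor. Compound 1 `CC1=C(/C=C/C(=O)/C=C/c2ccc(Cl)cc2)C(C)(C)CCC1` gives 52300 nM, compound 2 `CC1=C(/C=C/C(=O)/C=C/c2ccc(Br)cc2)C(C)(C)CCC1` gives 10400 nM, and compound 3 `CC1=C(/C=C/C(=O)/C=C/c2ccc(F)cc2)C(C)(C)CCC1` gives 7400 nM. Within the data shown here, compound 3 has the lowest number of the three, but its gap to compound 2 lies within the scatter, so those two cannot be told apart; only the step of a 7.1-fold lower number from compound 1 to compound 3 (0.85 log units; beyond the scatter) stands out clearly. Compound 4 `CC1=C(/C=C/C(=O)/C=C/c2ccccc2C)C(C)(C)CCC1` differs from compound 3 in one place: 2-methylphenyl in place of 4-fluorophenyl on a double-bonded chain carbon bound to a double-bonded chain carbon. The measured steps, a 5.0-fold lower number from compound 1 to compound 2 (0.70 log units; beyond the scatter) and a 1.4-fold lower number from compound 2 to compound 3 (0.15 log units; within the scatter) among them, all swap one halogen for another, so none speaks directly to 2-methylphenyl in place of 4-fluorophenyl. With no guide, the expected step is a 1.6-fold higher number from compound 3 to compound 4 (0.21 log units; within the scatter), which may well fall within the scatter. Compound 4 is therefore estimated at 12000 nM, between 3500 nM and 40000 nM.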

Compound 4, half-maximal inhibitory concentration: 63200 nM
Compound 4: the middle estimate sits 5.3-fold (0.72 log units) below what was measured; measured number outside the range, above it.
By their numbers in this assay, from the lowest: compounds 3 and 2 (each within the scatter of the next); then compounds 1 and 4 (each within the scatter of the next).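

In this assay this place on the chain is sensitive to more than a swap of halogen: 2-methylphenyl in place of 4-fluorophenyl gives the step (an 8.5-fold higher number from compound 3 to compound 4 (0.93 log units; beyond the scatter)), and in place of 4-bromophenyl it gives the step (a 6.1-fold higher number from compound 2 to compound 4 (0.78 log units; beyond the scatter)). In place of 4-chlorophenyl, the step (a 1.2-fold higher number from compound 1 to compound 4 (0.08 log units; within the scatter)) leaves compound 4 indistinguishable from compound 1, so the outcome depends on which halogen compound serves as the comparison. No evidence here explains these steps.

Compound 4 alters both the substituent and its place on the ring, so the compounds shown cannot separate those two changes. Going by these compounds, how a phenyl ring carrying an amine or a carboxylic acid would behave at this place also remains open.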